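The compounds below may be only part of what the source reports. "The series", "measured", "known", "first", "only" and "open" are said of these compounds alone.

Of the compounds shown here, two sharing one core have been measured so far in an ADME assay on microsomes from liver (Mus musculus) for metabolic stability, read by LC-MS, with a stated time of 10 min (on this read-out higher numbers stand for a more stable compound and lower numbers for a less stable compound), on this series. Compound 1 `C[C@@H]1CN(c2cccc3c2C[C@H](CN(C)[C@H]2CCCc4cccnc42)NC3)C[C@H](C)N1` gives 85.6% there, while compound 2 `CN(C[C@H]1Cc2c(cccc2N2CCN3CCC[C@H]3C2)CN1)[C@H]1CCCc2cccnc21` gives 40.1% and so holds the lower of the two numbers. Compound 3 `CN1CCN(c2cccc3c2C[C@H](CN(C)[C@H]2CCCc4cccnc42)NC3)CC1` has not yet been measured. It differs from compound 2 on an aromatic carbon, where a group of 7 heavy atoms (5 carbon, 2 nitrogen; one six-membered non-aromatic ring with 2 hetero atoms) in place of a group of 9 heavy atoms (7 carbon, 2 nitrogen; one five-membered non-aromatic ring with 1 hetero atom, one six-membered non-aromatic ring with 2 hetero atoms), on an aromatic carbon describes the change, with 4-methylpiperazin-1-yl entering. For the measured compounds named here, one measured step bears on this, namely a number 45.5 percentage points lower from compound 1 to compound 2 (beyond the scatter) on a change of group on an aromatic carbon, and it is large. Going by the values given here, the group that compound 3 loses is the one that compound 2 gained in that step, so a moderate rise beyond the scatter is expected, although a single step fixes its size only loosely. The estimated change is a number 21.9 percentage points higher from compound 2 to compound 3 (beyond the scatter) in this assay on this reading. Compound 3 is expected at 62% with an estimated range from 40% to 82% as its likely span.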

Compound 3, percent of the compound remaining: 17%
Beside the measured number, compound 3's estimate is 45 percentage points above it, outside the stated range (below it).
By their numbers in this assay, from the lowest: compound 3; then compound 2; then compound 1.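

In this assay, 4-methylpiperazin-1-yl on this aromatic carbon gives a number 23.1 percentage points lower from compound 2 to compound 3 (beyond the scatter), and set against 3,5-dimethylpiperazin-1-yl it gives a number 68.6 percentage points lower from compound 1 to compound 3 (beyond the scatter). The position is therefore sensitive to more than the size of the group: the group with the fewest heavy atoms, in compound 3, has the lowest number, the largest, in compound 2, the middle one, and compound 1 the highest. Nothing available explains these differences.

From the compounds shown here alone, it remains open where plain piperazin-1-yl or morpholin-4-yl on this carbon would fall relative to compound 1 and compound 3. Also open, going by these compounds, is whether 3-methylpiperazin-1-yl would stand nearer to compound 1 or to compound 3 in this assay.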